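Rat plasma half-life: nitrooxymethyl ester in place of aryl ester

The source may report more compounds than this note shows. Statements on the series, on what has been measured and on what is new or still open speak of the compounds shown alone.

Measured compounds:
compound 1 `CC(=O)Oc1ccccc1C(=O)O[C@H]1CO[C@H]2[C@@H]1OC[C@H]2OC(=O)c1ccc(O)cc1`: 0.0198 h
compound 2 `CC(=O)Oc1ccccc1C(=O)O[C@H]1CO[C@H]2[C@@H]1OC[C@H]2OC(=O)c1cccc(C)c1`: 0.0203 h
compound 3 `CC(=O)Oc1ccccc1C(=O)O[C@H]1CO[C@H]2[C@@H]1OC[C@H]2OC(=O)c1cnoc1C`: 0.001 h

In an ADME assay on a cell-free system (plasma, Homo sapiens) for metabolic stability, with Plasma (Rattus norvegicus) as the target, read by HPLC, at pH 7.4 (on this read-out higher numbers stand for a longer-lived compound and lower numbers for a shorter-lived compound), compound 2 gives 0.0203 h, the highest of the three numbers, with compound 1 within the scatter of it and compound 3 far lower. The two steps that change the ester group on the same carbonyl carbon point in different ways: a 1.0-fold higher number from compound 1 to compound 2 (0.01 log units; within the scatter), whereas a 20-fold lower number from compound 2 to compound 3 (1.31 log units; beyond the scatter) and a 20-fold lower number from compound 1 to compound 3 (1.30 log units; beyond the scatter). So an exchange of one six-membered aromatic ring for another leaves the number where it was, while leaving the aromatic carbocycle altogether has so far come with a large drop.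

Compound 4 `CC(=O)Oc1ccccc1C(=O)O[C@H]1CO[C@H]2[C@@H]1OC[C@H]2OC(=O)CO[N+](=O)[O-]` is not yet measured. It differs from compound 2 thus: (nitrooxy)methyl in place of 3-methylphenyl on a carbonyl carbon. Among the measured compounds shown here, because the only step that removes the carbocyclic aryl group, a 20-fold lower number from compound 2 to compound 3 (1.31 log units; beyond the scatter), was large and downward, a step of similar direction is expected here, though the entering group is not an aromatic ring and the size is uncertain. For compound 4 the expected value in this assay is 0.006 h (range 0.001 h to 0.02 h), which would mean a 3.4-fold lower number from compound 2 to compound 4 (0.53 log units; beyond the scatter).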

Compound 4, half-life: 0.015 h
For compound 4 the middle estimate is 2.5-fold (0.40 log units) below the measured one, within the range that was stated.
By their numbers in this assay, from the lowest: compound 3; then compounds 4, 1 and 2 (each within the scatter of the next).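

At this carbonyl carbon, an aromatic carbocycle is not required to keep the number at the level of the aryl esters in this assay: the ring-free (nitrooxy)methyl group gives a 1.4-fold lower number from compound 2 to compound 4 (0.13 log units; within the scatter) and a 1.3-fold lower number from compound 1 to compound 4 (0.12 log units; within the scatter), both within the scatter. Among the compounds shown here, the large drop with 5-methyl-1,2-oxazol-4-yl therefore does not follow from loss of the carbocycle alone, and a 15-fold higher number from compound 3 to compound 4 (1.18 log units; beyond the scatter) leaves compound 3 as the only short-lived member of the four. Nothing available explains why this one group differs from the other three.

Still open, from the compounds shown here alone, is whether the number holds with a longer chain carrying the nitrooxy group, or with a plain methyl in place of (nitrooxy)methyl. The half-life alone also does not show which of the two ester groups is lost first.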